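Notes on the stereocentre drawn in compound 3

The compounds below may be only part of what the source reports. "The series", "measured", "known", "first", "only" and "open" are said of these compounds alone.

Values in a functional assay on HeLa cells (Homo sapiens) for antiproliferative activity, read by MTT assay, with a stated time of 72 h (a higher number here means a weaker inhibitor, a lower number a stronger inhibitor), follow.
- compound 1 `NC1CCc2nc(-c3ccncc3)nc(Nc3ccc(F)cc3)c2C1` gives 20800 nM
- compound 2 `NC1CCc2nc(-c3ccncc3)nc(Nc3cccc(F)c3)c2C1` gives 17000 nM
- compound 3 `N[C@H]1CCc2nc(-c3ccncc3)nc(Nc3cccc(F)c3)c2C1` is not yet measured

Compound 2 lies within the scatter of compound 1. Compound 3 differs from compound 2 as follows: the two compounds have the same atoms and bonds; at least one stereo element is drawn with a configuration in one of them and without one in the other: 1 of 1 stereo elements differ; a stereocentre at a saturated ring carbon is drawn without a configuration in compound 2 and S in compound 3. Among the measured compounds shown here, the one measured step, a 1.2-fold lower number from compound 1 to compound 2 (0.09 log units; within the scatter), exchanges 4-fluorophenyl for 3-fluorophenyl and leaves the stereocentre untouched, so it offers no direct guide. For the measured compounds named here, no measured pair tests a configuration. No step beyond the scatter is therefore expected in this assay, and no direction is favoured. The expected step is a 1.1-fold lower number from compound 2 to compound 3 (0.05 log units; within the scatter). The estimate for compound 3 is 15000 nM, with an expected range of 7000 nM to 32000 nM.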

Compound 3, half-maximal inhibitory concentration: 17100 nM
Compound 3: middle estimate off by 1.1-fold (0.06 log units), on the low side, within the range that was stated.
By their numbers in this assay, from the lowest: compounds 2, 3 and 1 (each within the scatter of the next).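

In this assay, among the compounds shown here, the S drawing at the saturated ring carbon comes with a 1.0-fold higher number from compound 2 to compound 3 (0.00 log units; within the scatter), the first pair to touch this stereocentre. Defining it as S therefore leaves the number within the scatter of the undefined drawing. The reading has one limit: the fact that one of compounds 2 and 3 is drawn with a defined configuration and the other without, at the place where they differ

As far as these compounds go, the value of the R configuration on the same core remains open, so no preference between the two configurations can be stated. Also open, from the compounds shown here alone, is how an acetamide or a dimethylamino group in place of the amine would read against compound 3 in this assay.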